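Four Heavy Atoms in Place of One Oxygen on the Chain

A few compounds are considered here, and "the series" means these few. Any claim that something is new, unique, unknown or untested is made for them only; others in the source may bear on it.

Compound 1 `CC(C)c1n[nH]c2c(NCc3ccc(-c4ccccn4)cc3)nc(SCCO)nc12` holds the lower of the two numbers measured in a functional assay on HT cells (Homo sapiens) for antiproliferative activity, read by fluorescence, with a stated time of 72 h; a lower number here means a stronger inhibitor of growth, a higher number a weaker inhibitor of growth; compound 1 gives 48 nM. Going by the values given here, its only neighbour, compound 2 `CC(C)c1n[nH]c2c(NCc3ccc(-c4ccccn4)cc3)nc(SCCCO)nc12`, gives 109 nM, and the step of a 2.3-fold higher number from compound 1 to compound 2 (0.36 log units; beyond the scatter) is the sole measured change at this end of the molecule. Compound 3 `CC(C)c1n[nH]c2c(NCc3ccc(-c4ccccn4)cc3)nc(SCCNC(=N)N)nc12` differs from compound 1 as follows: a group of 4 heavy atoms (1 carbon, 3 nitrogen; no ring) in place of one oxygen atom, on a saturated chain carbon, two bonds along the chain from a sulfur. Among the compounds with values here, no measured step exchanges the oxygen itself; the step from compound 1 to compound 2 only puts hydroxymethyl in place of hydroxy and costs a modest amount, so it tells only that this position tolerates some growth with a small loss. The larger change in compound 3 therefore carries wide uncertainty, and the expected step of a 1.9-fold higher number from compound 1 to compound 3 (0.27 log units; within the scatter) is a mild weakening. Compound 3 is estimated at 90 nM in this assay, within a range of 25 nM to 350 nM.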

Compound 3, concentration for 50% growth inhibition: 390 nM
The estimate for compound 3 lay 4.3-fold (0.64 log units) below the measured number; measured number above the stated range.
By their numbers in this assay, from the lowest: compound 1; then compound 2; then compound 3.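

Placing the group of 4 heavy atoms on the saturated chain carbon, two bonds along the chain from a sulfur, brings an 8.1-fold higher number from compound 1 to compound 3 (0.91 log units; beyond the scatter) in this assay and shows that this position does not accept every larger group with only a small loss. The same group also brings a 3.6-fold higher number from compound 2 to compound 3 (0.55 log units; beyond the scatter) and so falls behind the hydroxymethyl-extended chain as well as the original hydroxy chain. No measurement at hand accounts for these losses.

As far as these compounds go, it remains open whether the loss follows the whole group of 4 heavy atoms or only part of it, a question that a simple amine or a urea at the same place could help to divide. A carboxylic acid at this place, or a longer chain carrying the same group, would show how far the position's limits extend.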